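The source may report more compounds than this note shows. Statements on the series, on what has been measured and on what is new or still open speak of the compounds shown alone.

Measured in a functional assay on HeLa cells (Homo sapiens) for cytotoxicity, read by ELISA, with a stated time of 4 days; on this read-out higher numbers stand for weaker inhibition and lower numbers for stronger inhibition:

- compound 1 `Clc1ccc(-c2cc(-c3ccco3)cc(-c3ccc(Cl)s3)n2)cc1`: 17000 nM
- compound 2 `Cc1ccc(-c2cc(-c3ccc(Cl)o3)cc(-c3ccc(Cl)s3)n2)cc1`: > 50000 nM

Compound 2 stands at > 50000 nM, which is a limit of the assay and not a number. It therefore gives no exact starting point for the next comparison. Compound 1 gives 17000 nM, a measured number in this assay. The two compounds differ in more than one place, so no single change in this series has a measured size.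

Compound 3 `Clc1ccc(-c2cc(-c3ccc(Cl)o3)cc(-c3ccc(Cl)s3)n2)cc1` comes from compound 2 through one change, chloro in place of methyl on an aromatic carbon, or 4-methylphenyl to 4-chlorophenyl. In this assay, a modest move towards stronger inhibition is expected, although compound 3 may also end at a limit. The expectation of a number rests on compound 1 at 17000 nM, which shows that a member of this series can give a value within the measurable range. The expected change is an at least 1.6-fold lower number from compound 2 to compound 3 (0.22 log units; that floor lies within the scatter). For compound 3 the estimated value is 30000 nM, with an expected range of 12000 nM to 50000 nM.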

Compound 3, half-maximal inhibitory concentration: 25100 nM
Beside the measured number, compound 3's estimate is 1.2-fold (0.08 log units) above it; measured number inside the range.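

With chloro in place of methyl on an aromatic carbon, para to a large group, the result in this assay moves from a limit to a number, giving the first read on this position (an at least 1.9-fold lower number from compound 2 to compound 3 (0.29 log units; that floor lies within the scatter)). Chloro in place of hydrogen on an aromatic carbon gives a step that this assay does not resolve (a 1.5-fold higher number from compound 1 to compound 3 (0.17 log units; within the scatter)), so the chloro added in this second change cannot be told apart from the hydrogen it replaces on this read-out. Compound 2 stands at > 50000 nM, a limit and not a number, so the step from it gives only a floor and not a true size: the limit of > 50000 nM in this assay, at which 1 of the 3 values shown sits.

Going by these compounds, the real size of the change from 4-methylphenyl to 4-chlorophenyl stays open, as does whether it would look the same in a compound that carries hydrogen where compound 1 does. On these data alone, how an amine, a methoxy group, a carboxylic acid or a longer chain in place of chloro on the 4-chlorophenyl would read in this assay also remains open.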